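A few compounds are considered here, and "the series" means these few. Any claim that something is new, unique, unknown or untested is made for them only; others in the source may bear on it.

The measured compounds and their numbers:

Compound 1, `CC1=NN(C(=O)CN2CCN(C)CC2)C(c2ccccc2O)C1` — 11800 nM
Compound 2, `COc1ccccc1C1CC(C)=NN1C(=O)CN1CCC(OC)CC1` — 27200 nM
Compound 3, `CNCC(=O)N1N=C(c2cc3ccccc3oc2=O)CC1c1ccccc1` — 2300 nM

All three were tested in a functional assay on PC-3 cells (Homo sapiens) for cytotoxicity, read by MTT assay, with a stated time of 48 h; on this read-out higher numbers stand for weaker inhibition and lower numbers for stronger inhibition. Compound 3 stands at the lowest number of the three and is therefore the strongest inhibitor of the set: compound 1 gives a value beyond the scatter above it, and compound 2 lies further still. Compounds 1 and 2 share a different core from compound 3, so nothing in these three numbers isolates a single structural change.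

Compound 4, `CCN(CC)C1CCN(CC(=O)N2N=C(c3cc4ccccc4oc3=O)CC2c2ccccc2)CC1`, keeps the core of compound 3 and differs from it at one place: 4-(diethylamino)piperidin-1-yl in place of methylamino on a saturated chain carbon bound to a carbonyl carbon. Among the measured compounds shown here, no pair of measured compounds differs in one place, so there is no measured step of this kind to lean on; what can be said rests on the value of compound 3 alone.

For the measured compounds named here, with no comparable step on hand, the change is expected to move the number only modestly, if at all, in this assay. The step from compound 3 to compound 4 is estimated at a 1.3-fold lower number from compound 3 to compound 4 (0.11 log units; within the scatter), which stays within the scatter. Compound 4 is thus expected to give about 1800 nM, with a plausible range from 700 nM to 4500 nM.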

Compound 4, half-maximal inhibitory concentration: 26100 nM
Compound 4: the middle estimate sits 15-fold (1.16 log units) below what was measured, outside the stated range (above it).
By their numbers in this assay, from the lowest: compound 3; then compound 1; then compounds 4 and 2 (each within the scatter of the next).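

In this assay, among the compounds shown here, the saturated chain carbon bound to a carbonyl carbon proves to be a sensitive place: replacing methylamino with 4-(diethylamino)piperidin-1-yl gives an 11-fold higher number from compound 3 to compound 4 (1.05 log units; beyond the scatter) and provides the first single-place comparison in the set. The change runs towards weaker inhibition, so on this core the group with 11 heavy atoms and a six-membered non-aromatic ring does not hold the number set by the 2 heavy atoms of methylamino. Nothing at hand explains this step.

Going by these compounds, the exchange changes several things at once, adding the ring and the diethylamino group and going from 1 hydrogen-bond donor to 0, so it remains open which of these goes with the higher number. On these data alone, an unsubstituted piperidin-1-yl or a dimethylamino group on the same carbon would help to separate the ring from the diethylamino group, and it also remains open whether a similar exchange would move the number in the same direction on the core of compound 1.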